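Naphthalen-2-yl sulfonate: testing the limit in DU-145 cells

The source may report more compounds than this note shows. Statements on the series, on what has been measured and on what is new or still open speak of the compounds shown alone.

In a functional assay on DU-145 cells (Homo sapiens) for inhibition, read by MTT assay, with a stated time of 72 h (on this read-out higher numbers stand for weaker inhibition and lower numbers for stronger inhibition), compound 1 `O=S(=O)(Oc1ccccc1)[C@H]1C[C@H]2O[C@@H]1C(c1ccc(O)cc1)=C2c1ccc(O)cc1` gives > 100000 nM, a limit and not a number. Compound 2 `Cc1ccccc1OS(=O)(=O)C1CC2OC1C(c1ccc(NC(=O)CCCCCCC(=O)O)cc1)=C2c1ccc(O)cc1` gives > 100000 nM, also only a limit. Among the compounds with values here, the series so far thus shows (the limit of > 100000 nM in this assay, at which 2 of the 2 values shown sit). Compound 3 `O=C(O)CCCCCCC(=O)Nc1ccc(C2=C(c3ccc(O)cc3)C3CC(S(=O)(=O)Oc4ccc5ccccc5c4)C2O3)cc1` carries naphthalen-2-yl in place of 2-methylphenyl on an oxygen. No measured step sizes this change in this assay, so only a small move toward stronger inhibition, or none beyond the scatter, is expected. The expected step is an at least 1.4-fold lower number from compound 2 to compound 3 (0.15 log units; that floor lies within the scatter). For compound 3 the estimated value is 70000 nM, with an expected range of 15000 nM to 150000 nM.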

Compound 3, half-maximal inhibitory concentration: 58300 nM
Compound 3: the middle estimate sits 1.2-fold (0.08 log units) above what was measured, and the stated range covers the measured number.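

Within the data shown here, with naphthalen-2-yl on the oxygen bonded to the sulfonyl sulfur, compound 3 gives the first value in this assay that is a number rather than a limit. On these data alone, the change reads as an at least 1.7-fold lower number from compound 2 to compound 3 (0.23 log units; that floor lies within the scatter), so only a floor is known, and the true size of the step remains unknown. The other compounds stay at a limit: the limit of > 100000 nM in this assay, at which 2 of the 3 values shown sit.

As far as these compounds go, it remains open whether a second aromatic ring is enough, since naphthalen-1-yl or a quinoline on this oxygen would test that. From the compounds shown here alone, the effect of an amine on the aromatic group or a longer chain on the anilide also remains unknown.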